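Adding a Hydroxy Group to Compound 2

The source may report more compounds than this note shows. Statements on the series, on what has been measured and on what is new or still open speak of the compounds shown alone.

Compound 1, `Cc1[nH]c2ccccc2c(=O)c1/C=C/C(=O)OC(C)(C)C`: in a physicochemical assay for lipophilicity, at pH 7.4 (on this read-out higher numbers stand for higher lipophilicity and lower numbers for lower lipophilicity), compound 1 gives 2.34.
Compound 2, `Cc1[nH]c2ccccc2c(=O)c1/C=C/c1ccccc1`: in this assay compound 2 gives 4.4.

Compound 2 stands highest of the two measured numbers; its nearest neighbour is compound 1, and the step of a number 2.06 log units higher from compound 1 to compound 2 (beyond the scatter) is large and beyond the scatter. Compound 3, `Cc1[nH]c2ccccc2c(=O)c1/C=C/c1ccc(O)cc1`, differs from compound 2 by hydroxy in place of hydrogen on an aromatic carbon. Going by the values given here, none of the measured steps involves a hydroxy group, so the one step in hand, from compound 1 to compound 2, concerns a different change and only shows how far numbers on this shared core can move. The expectation therefore rests on the change itself: an oxygen bringing one hydrogen-bond donor and one acceptor. Compound 3 is expected to come out lower in this assay than compound 2, by a step of a number 0.60 log units lower from compound 2 to compound 3 (beyond the scatter). For compound 3 the estimate is 3.8, with a range from 3.3 to 4.3.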

Compound 3, distribution coefficient: 1.77
The estimate for compound 3 lay 2.03 log units above the measured number, outside the stated range (below it).
By their numbers in this assay, from the lowest: compound 3; then compound 1; then compound 2.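

In this assay, one hydroxy in place of hydrogen on an aromatic carbon, para to a large group, gives a number 2.63 log units lower from compound 2 to compound 3 (beyond the scatter). This small exchange at a single position therefore moves the number at least as visibly as replacing a whole group did in the earlier step, a number 2.06 log units higher from compound 1 to compound 2 (beyond the scatter). It also reverses the order against tert-butoxycarbonyl: phenyl stood above that group, but with 4-hydroxyphenyl the result is a number 0.57 log units lower from compound 1 to compound 3 (beyond the scatter), and nothing available explains the size of this drop.

The compounds shown leave open whether a methoxy group or an amine at the same place would bring a similar step. They also leave open whether a hydroxy group elsewhere on the same ring would move the number this far.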